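The compounds below may be only part of what the source reports. "The series", "measured", "known", "first", "only" and "open" are said of these compounds alone.

Of the compounds shown here, two sharing one core have so far been measured in a functional assay on M14 cells (Homo sapiens) for cytotoxicity; on this read-out lower numbers stand for stronger inhibition of growth and higher numbers for weaker inhibition of growth. In this test, compound 1 `CSc1ccc(C2=C(c3ccc(F)c(F)c3)C(=O)N3CCCC3C2)cc1` gives 300 nM. Compound 2 `CSc1ccc(C2=C(c3ccc(OCC4CO4)cc3)C(=O)N3CCCC3C2)cc1` gives 90 nM, which leaves compound 1 with the higher of the two numbers, and the gap between them lies beyond the usual scatter. Compound 3 `CSc1ccc(C2=C(c3ccc(C)cc3)C(=O)N3CCCC3C2)cc1` has not yet been measured. It keeps the core of compound 1 and the 4-(methylsulfanyl)phenyl group, and the change is 4-methylphenyl in place of 3,4-difluorophenyl on a double-bonded ring carbon. Among the compounds with values here, no measured pair shows this change on its own, so the expectation rests on thin evidence. Compound 2 carries a different group at this same place and reads 90 nM, so a change there can go with a shift in the number, though that pair cannot be read as a trend. In this assay, no step beyond the scatter is expected, with a slight lean towards a lower number. The expected step is a 1.5-fold lower number from compound 1 to compound 3 (0.18 log units; within the scatter). Compound 3 is estimated at 200 nM, within a range of 60 nM to 650 nM.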

Compound 3, concentration for 50% growth inhibition: 6000 nM
For compound 3 the middle estimate is 30-fold (1.48 log units) below the measured one, and the stated range ends below it.
By their numbers in this assay, from the lowest: compound 2; then compound 1; then compound 3.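

In this assay, the group on the double-bonded ring carbon proves far less forgiving than the first two compounds could show: 4-methylphenyl in place of 3,4-difluorophenyl goes with a 20-fold higher number from compound 1 to compound 3 (1.30 log units; beyond the scatter), although each group is one six-membered aromatic ring of carbon only and carries no net charge. Methyl in place of (oxiran-2-yl)methoxy on an aromatic carbon of that ring goes with a 67-fold higher number from compound 2 to compound 3 (1.82 log units; beyond the scatter), so this one position now spans a much wider range of values than the gap between the first two compounds suggested. Nothing available explains why these changes shift the number so strongly.

The compounds shown do not separate the loss of the two fluorines from the arrival of the methyl, and a plain phenyl or a 4-fluorophenyl group at this place would help to tell these apart. They also leave open whether the oxirane ring or the ether oxygen goes with the low number of compound 2, which a simple methoxy or a longer alkoxy chain on the same aromatic carbon could address.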